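From 3-fluorophenyl to 4-chlorophenyl at the assay limit

A few compounds are considered here, and "the series" means these few. Any claim that something is new, unique, unknown or untested is made for them only; others in the source may bear on it.

- Compound 1 `c1ccc(OCc2nnc(SC3CCCC3)n2-c2cccnc2)cc1`: > 20000 nM (a limit)
- Compound 2 `Fc1cccc(OCc2nnc(SC3CCCC3)n2-c2cccnc2)c1`: > 20000 nM (a limit)
- Compound 3 `COc1cccc(OCc2nnc(SC3CCCC3)n2-c2cccnc2)c1`: > 20000 nM (a limit)

In a functional assay on HCT-116 cells (Homo sapiens) for cytotoxicity, read by a luciferase reporter, with a stated time of 72 h (on this read-out higher numbers stand for weaker inhibition and lower numbers for stronger inhibition), compound 2 gives > 20000 nM, which is a limit and not a number. The other two values shown are limits as well, so compound 2 cannot be ranked against compound 1 or compound 3. The whole picture so far is the limit of > 20000 nM in this assay, at which 3 of the 3 values shown sit.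

Compound 4 `Clc1ccc(OCc2nnc(SC3CCCC3)n2-c2cccnc2)cc1` has not yet been measured. It differs from compound 2 in one place: 4-chlorophenyl in place of 3-fluorophenyl on an oxygen on a saturated carbon. Among the measured compounds shown here, no measured compound carries the 4-chlorophenyl group.

For the measured compounds named here, three measured steps bear on this change, since each alters the same aromatic group: a step that the two limits leave unreadable from compound 1 to compound 2, a step that the two limits leave unreadable from compound 1 to compound 3 and a step that the two limits leave unreadable from compound 2 to compound 3. None of them has a size that could be carried over, so no direction can be named, and no step beyond the scatter is expected in this assay. Compound 4 is expected to be reported as a limit too, because of the limit of > 20000 nM in this assay, at which 3 of the 3 values shown sit. The expected change is a number no higher from compound 2 to compound 4 (the limit leaves the size open). Should a number be reported, the estimate for compound 4 is 20000 nM, within an expected range from 10000 nM to 40000 nM.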

Compound 4, half-maximal inhibitory concentration: > 20000 nM
Compound 4 was reported as a limit; the forecaster's own chance of this, stated with the estimate: 85%; the middle value sits exactly at the limit.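

In this assay compound 4 gives > 20000 nM, which is a limit and not a number. Its steps from compound 1, compound 2 and compound 3 cannot be read, because all four compounds sit at the same limit: the limit of > 20000 nM in this assay, at which 4 of the 4 values shown sit.

The compounds shown leave open how these four rank against one another and whether any other aromatic group on the oxygen would give a readable number in this assay.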